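A few compounds are considered here, and "the series" means these few. Any claim that something is new, unique, unknown or untested is made for them only; others in the source may bear on it.

In a functional assay on the whole organism (strain Sprague-Dawley) for inhibition, with Rattus norvegicus as the target, with a stated time of 10 min (on this read-out lower numbers stand for an effect already at smaller amounts and higher numbers for an effect only at larger amounts of compound), compound 2 `CCOC(=O)c1cnc(-c2ccccc2OCC)[nH]c1=O` gives 2 mg/kg. Compound 3 `CCCCCOc1ccccc1-c1ncc(C(=O)OCC)c(=O)[nH]1` gives 2 mg/kg, and no change at the digits printed from compound 2 to compound 3 (within the scatter). Compound 1 `CCOC(=O)c1cnc(-c2ccccc2F)[nH]c1=O` gives > 10 mg/kg, which is a limit of the assay and not a number. Measured from that limit, an at least 5.0-fold lower number from compound 1 to compound 2 (0.69 log units; beyond the scatter), and likewise an at least 5.0-fold lower number from compound 1 to compound 3 (0.69 log units; beyond the scatter). Compound 2 therefore stands level with compound 3, and only compound 1 sits apart, at the limit (the limit of > 10 mg/kg in this assay, at which 1 of the 3 values shown sits).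

The compound still to be tested is compound 4 `CCOC(=O)c1cnc(-c2cc(S(N)(=O)=O)ccc2OCC)[nH]c1=O`. It differs from compound 2 in one place: sulfamoyl in place of hydrogen on an aromatic carbon.

Among the measured compounds shown here, none of the measured steps touches this kind of change. For the measured compounds named here, the two steps leading away from compound 1 concern swapping fluoro for an ether, and the step between compound 2 and compound 3 concerns the length of the ether chain; no measured compound carries a sulfamoyl group anywhere. Going by the values given here, with no step to lean on, the step expected in this assay is a 1.5-fold higher number from compound 2 to compound 4 (0.18 log units; within the scatter), that is, none beyond the scatter, with a wide range on either side. Compound 4 is estimated at 3 mg/kg, between 1 mg/kg and 10 mg/kg.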

Compound 4, dose for 50% inhibition: 50 mg/kg
For compound 4 the middle estimate is 17-fold (1.22 log units) below the measured one; the measured number lies above the stated range.
By their numbers in this assay, from the lowest: compounds 2 and 3 (each within the scatter of the next); then compound 4.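

The earlier compounds shown here changed only the group on one ring carbon, swapping fluoro for an ether or lengthening that ether, and left the other ring positions as hydrogen. In this assay, sulfamoyl in place of hydrogen on an aromatic carbon, para to an ethoxy group, brings a 25-fold higher number from compound 2 to compound 4 (1.40 log units; beyond the scatter), so a much larger dose is needed for the same effect and this ring position is clearly not indifferent to change, whereas extending the ether chain gave no change at the digits printed from compound 2 to compound 3 (within the scatter). Nothing shown here measures a property of the sulfamoyl group that would account for this step.

With a single group at this position, the compounds shown leave open whether the large step belongs to sulfamoyl itself or would come with any group on this carbon, and a small methyl group, a chlorine atom, an amine or a carboxylic acid in the same place would help to separate the two. From the compounds shown here alone, it also stays open whether sulfamoyl at this position would have the same effect alongside the pentyloxy chain of compound 3.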